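This account rests on a few compounds, and the source may have more. Where it says the series, first, only, none or still open, it means among the compounds named here.

Compound 3 `CCOc1ccccc1-c1ccc(-c2nc3cnccc3c(NC(C)C(=O)O)c2C#N)cc1` gives 2.1 in a physicochemical assay for lipophilicity, read by HPLC, at pH 7.5 (on this read-out higher numbers stand for higher lipophilicity and lower numbers for lower lipophilicity), the lowest of the three measured values. Compound 2 `CCOc1ccccc1-c1ccc(-c2nc3cnccc3c(NC(C(N)=O)C3CC3)c2C#N)cc1` gives 3, and compound 1 `CCCCC(Nc1c(C#N)c(-c2ccc(-c3ccccc3OCC)cc2)nc2cnccc12)C(N)=O` gives 3.6. The move to compound 4 `CCOc1ccccc1-c1ccc(-c2nc3cnccc3cc2C#N)cc1` is hydrogen in place of (1-carboxyethyl)amino on an aromatic carbon. The nearest measured guide is the step of a number 0.90 log units lower from compound 2 to compound 3 (beyond the scatter), and the larger step of a number 1.50 log units lower from compound 1 to compound 3 (beyond the scatter), both going downward as the (1-carboxyethyl)amino side is reached. Taking that side away entirely is therefore expected to push the value upward by a sizeable amount, estimated as a number 1.70 log units higher from compound 3 to compound 4 (beyond the scatter). Compound 4 is estimated to give 3.8 in this assay, with a range from 3.2 to 4.4.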

Compound 4, distribution coefficient: 3.8
The estimate for compound 4 equals the measured number at the digits printed, within the range that was stated.
By their numbers in this assay, from the lowest: compound 3; then compound 2; then compounds 1 and 4 (each within the scatter of the next).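

On this aromatic carbon, this assay now compares hydrogen with the substituted amino groups: the number rises when the (1-carboxyethyl)amino group is removed (a number 1.70 log units higher from compound 3 to compound 4 (beyond the scatter)) and when the cyclopropyl-bearing group is removed (a number 0.80 log units higher from compound 2 to compound 4 (beyond the scatter)). Removing the butyl-bearing group makes no clear difference (a number 0.20 log units higher from compound 1 to compound 4 (within the scatter)), so replacing these groups with hydrogen has no single effect across the three compounds. Nothing measured here explains these differences.

Going by these compounds, it remains open how a plain amino group or a methoxy group on this carbon would compare with hydrogen.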